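Pentan-3-yloxy Replacing Methoxyethylamino on the Shared Core

The source may report more compounds than this note shows. Statements on the series, on what has been measured and on what is new or still open speak of the compounds shown alone.

Compound 1 `COCCNc1nc(C)nc2c1ncn2-c1ccc(C(C)C)cc1Br` gives 210 nM in an in vitro assay on 293-EBNA cells for binding affinity to corticotropin-releasing factor receptor 1 (Homo sapiens) (on this read-out higher numbers stand for weaker inhibition and lower numbers for stronger inhibition), the highest of the three numbers measured. Compound 3 `CCCCN(CC)c1nc(C)nc2c1nc(-c1ccccc1)n2-c1c(Cl)cc(OC)cc1OC`, at 133 nM, sits nearest to it, within the scatter, while compound 2 `CCCCN(CC)c1nc(C)nc2c1ncn2-c1c(Cl)cc(OC)cc1OC`, at 5.2 nM, lies furthest from it, beyond the scatter. For the measured compounds named here, the only single-point step among the measured compounds is a 26-fold higher number from compound 2 to compound 3 (1.41 log units; beyond the scatter), which concerns a substituent elsewhere on the core and does not bear on the present change. Compound 4 `CCC(CC)Oc1nc(C)nc2c1ncn2-c1ccc(C(C)C)cc1Br` differs from compound 1 by (pentan-3-yl)oxy in place of (2-methoxyethyl)amino on an aromatic carbon. Going by the values given here, no measured pair isolates this exchange; compound 2 carries a different amino group at the same carbon together with a different aryl group, so its value cannot be read across. The expectation for compound 4 is therefore guarded, a moderate step in the direction of stronger binding that may not clear the scatter, a 2.6-fold lower number from compound 1 to compound 4 (0.42 log units; beyond the scatter). Compound 4 is estimated at 80 nM, within a range from 15 nM to 400 nM.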

Compound 4, inhibition constant: 3.5 nM
Beside the measured number, compound 4's estimate is 23-fold (1.36 log units) above it; the whole stated range lies above it.
By their numbers in this assay, from the lowest: compounds 4 and 2 (each within the scatter of the next); then compounds 3 and 1 (each within the scatter of the next).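

On the shared core, at this aromatic carbon next to the ring nitrogen, (pentan-3-yl)oxy in place of (2-methoxyethyl)amino gives a 60-fold lower number from compound 1 to compound 4 (1.78 log units; beyond the scatter) in this assay, the first single-place step read at this position. The step shows that binding on this core responds strongly to the group held here, and that a low number does not need the hydrogen-bond donor of the group that leaves. No measurement at hand explains the size of this step.

The exchange alters the linking atom and the chain together, and the compounds shown do not separate the two; (pentan-3-yl)amino or (2-methoxyethyl)oxy on the same core would each change only one of them. As far as these compounds go, whether the exchange carries the same weight alongside the aryl group of compound 2 also remains open.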